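Working notes: from compound 3 to compound 4

A few compounds are considered here, and "the series" means these few. Any claim that something is new, unique, unknown or untested is made for them only; others in the source may bear on it.

Measured in an ADME assay on microsomes from liver (Homo sapiens) for metabolic stability, read by LC-MS, using NADPH, with stated times of 10 min and 30 min (a higher number here means faster removal of the compound, a lower number slower removal), each value a limit and not a number:
- compound 1 `CCC(=O)N[C@@H]1CCCc2c1cncc2N1C(=O)c2ccc(Cl)cc2[C@@H]1C`: < 3.5 mL/min/kg
- compound 2 `CCC(=O)N[C@@H]1CCCc2c1cncc2N1Cc2cc(Cl)ccc2C1=O`: < 3.5 mL/min/kg
- compound 3 `CCC(=O)N[C@@H]1CCCc2c1cncc2N1C(=O)c2ccc(Cl)cc2[C@H]1CC`: < 3.5 mL/min/kg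

Compound 3 stands at < 3.5 mL/min/kg, which is a limit. It shares this position with the other two compounds: the limit of < 3.5 mL/min/kg in this assay, at which 3 of the 3 values shown sit. Compound 4 `CCC(=O)N[C@@H]1CCCc2c1cncc2N1C(=O)c2ccc(Cl)cc2[C@H]1C` differs from compound 3 by hydrogen in place of methyl on a saturated chain carbon bound to a saturated ring carbon, in short ethyl to methyl. Among the compounds with values here, two measured steps bear on this change: a step that the two limits leave unreadable from compound 1 to compound 2 and a step that the two limits leave unreadable from compound 2 to compound 3. Neither gives a size, so no step beyond the scatter is expected in this assay. The expected result is a number no lower from compound 3 to compound 4 (the limit leaves the size open). For compound 4 the estimate is 3.5 mL/min/kg, with an expected range of 2.5 mL/min/kg to 6 mL/min/kg.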

Compound 4, clearance: < 3.5 mL/min/kg
Compound 4 was reported as a limit; the forecaster's own chance of this, stated with the estimate: 85%; the middle value lies on the limit itself.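

No new step can be read from compound 4 against compounds 1, 2 and 3, since all four values are limits: the limit of < 3.5 mL/min/kg in this assay, at which 4 of the 4 values shown sit.

The compounds shown leave open how these four compare in clearance, including the pair that differs only as drawn: the fact that compounds 1 and 4 differ only in the configuration as drawn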